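Methylating the phenol of a pyrazole urea

The source may report more compounds than this note shows. Statements on the series, on what has been measured and on what is new or still open speak of the compounds shown alone.

Compound 1 `O=C(Nc1cccc(-n2cc(-c3ccncc3)c(-c3cc(O)cc(Cl)c3)n2)c1)Nc1ccc(Cl)c(Cl)c1` is the higher of the two numbers measured in a functional assay on U-251 cells (Homo sapiens) for inhibition, read by sulforhodamine B assay, with a stated time of 48 h, tested at 100 uM; on this read-out lower numbers stand for a stronger effect and higher numbers for a weaker effect at the one concentration tested: compound 1 gives -57%. Among the measured compounds shown here, its companion compound 2 `COc1cc(Cl)cc(-c2nn(-c3cccc(NC(=O)Nc4cc(C(F)(F)F)cc(C(F)(F)F)c4)c3)cc2-c2ccncc2)c1` gives -92% in this assay, a value that lies below that of compound 1 by more than the scatter; no single-point step links the two, so only their values can be set side by side. Compound 3 `COc1cc(Cl)cc(-c2nn(-c3cccc(NC(=O)Nc4ccc(Cl)c(Cl)c4)c3)cc2-c2ccncc2)c1` has not yet been tested. It differs from compound 1 in one place: methyl in place of hydrogen on an oxygen on an aromatic ring. For the measured compounds named here, since no measured pair shows the effect of this change alone, its size must be guessed. Compound 3 is expected to move toward the lower numbers, with the step of a number 15 percentage points lower from compound 1 to compound 3 (beyond the scatter) judged to lie beyond the scatter, because compound 2 , which also carries the methoxy group, gives -92%. Compound 3 is accordingly estimated at -72%, with a range from -95% to -45%.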

Compound 3, a percentage reported as activity, at one concentration (the size of the read-out at that concentration, not a potency): -68%
For compound 3 the middle estimate is 4 percentage points below the measured one, within the range that was stated.
By their numbers in this assay, from the lowest: compound 2; then compound 3; then compound 1.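

In this assay, the change from hydroxy to methoxy now has a reading of its own, with the rest of the structure held constant: the step is a number 11 percentage points lower from compound 1 to compound 3 (beyond the scatter) and is modest but beyond the usual scatter. Compound 2 differs from compound 1 in more than one place, so it could not isolate this change. This position therefore tolerates methyl on the oxygen without loss of effect, and the hydrogen on that oxygen is not required for the effect seen here. Nothing at hand explains the step.

Going by these compounds, it remains open whether a longer chain on this oxygen, such as ethoxy, or an amine in place of the hydroxy would extend the shift. On these data alone, it is also open whether the same change would give a step of similar size on the urea carrying the groups of compound 2.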